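Methyl placement on the piperidin-2-yl side chain

The compounds below may be only part of what the source reports. "The series", "measured", "known", "first", "only" and "open" are said of these compounds alone.

Compound 1 `Cc1cc(C)cc(-c2c(O)nc3cc(Cl)c([N+](=O)[O-])cc3c2OCC[C@H]2CCCCN2)c1` is the reference point of this small set. In an assay on isolated protein for inhibition of Gonadotropin-releasing hormone receptor (Rattus norvegicus) (on this read-out lower numbers stand for stronger inhibition and higher numbers for weaker inhibition), compound 1 gives 10 nM, the lowest number among the three measured compounds. Compound 3 `Cc1cc(C)cc(-c2c(O)nc3cc(Cl)c([N+](=O)[O-])cc3c2OCC[C@@H]2CCC[C@H](C)N2)c1` gives 15 nM in this assay, and compound 2 `Cc1cc(C)cc(-c2c(O)nc3cc(Cl)c([N+](=O)[O-])cc3c2OCCC2NCCc3ccccc32)c1` gives 750 nM.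

Compound 4 `Cc1cc(C)cc(-c2c(O)nc3cc(Cl)c([N+](=O)[O-])cc3c2OCCC2CCC(C)CN2)c1` is the unmeasured analogue. Its change from compound 1 is: 5-methylpiperidin-2-yl in place of piperidin-2-yl on a saturated chain carbon, two bonds along the chain from an oxygen on an aromatic ring

Within the data shown here, two measured steps bear on it. Among the measured compounds shown here, the closest precedent is a 1.5-fold higher number from compound 1 to compound 3 (0.18 log units; within the scatter), a methyl added to the same piperidin-2-yl ring, which stays within the scatter. The step of a 75-fold higher number from compound 1 to compound 2 (1.88 log units; beyond the scatter) shows that exchanging the ring for 1,2,3,4-tetrahydroisoquinolin-1-yl costs heavily, but that is a far larger change than a single methyl. For compound 4 the methyl sits on another ring carbon and no stereocentre is defined, so a somewhat wider range is allowed. The expected step for compound 4 is a 2.0-fold higher number from compound 1 to compound 4 (0.30 log units; within the scatter), nothing clearly beyond the scatter. Compound 4 is estimated at 20 nM, range 6 nM to 70 nM.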

Compound 4, half-maximal inhibitory concentration: 63 nM
Estimate against measurement, compound 4: 3.2-fold (0.50 log units) below; the range from low to high includes it.
By their numbers in this assay, from the lowest: compounds 1 and 3 (each within the scatter of the next); then compound 4; then compound 2.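

Moving the methyl on the piperidin-2-yl ring changes the outcome: 5-methylpiperidin-2-yl gives (a 6.3-fold higher number from compound 1 to compound 4 (0.80 log units; beyond the scatter)), whereas the 6-methylpiperidin-2-yl of compound 3 stayed within the scatter of compound 1. The two methylated rings also separate from each other (a 4.2-fold higher number from compound 3 to compound 4 (0.62 log units; beyond the scatter)), although compound 4 has no defined stereocentre in this ring, so methyl placement cannot be read apart from stereochemistry in this pair. Compound 4 still lies well clear of the 1,2,3,4-tetrahydroisoquinolin-1-yl analogue (a 12-fold lower number from compound 2 to compound 4 (1.08 log units; beyond the scatter)), so the added methyl costs much less than that ring exchange.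

No data at hand account for the gap between the two methyl placements. Open questions are how the separate stereoisomers of compound 4 compare and whether 5-ethylpiperidin-2-yl or 5-hydroxypiperidin-2-yl would follow the 5-methylpiperidin-2-yl result.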